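The source may hold more compounds than are shown below. What is called first, only, known or untested is meant among the compounds shown, and "the series" means these compounds.

The core of compound 1 (`COC(=O)N[C@H](C(=O)NN(CCC[C@@](O)(Cc1ccccc1)C(=O)N[C@H]1c2ccccc2C[C@H]1O)Cc1ccc(-c2ccccn2)cc1)C(C)(C)C`) carries a pyridin-2-yl group. In an ADME assay on MT4 cells (Homo sapiens) for cytotoxicity (on this read-out lower numbers stand for higher toxicity in this test and higher numbers for lower toxicity in this test), compound 1 gives > 10000 nM as a limit of the assay and not a number. Compound 2 (`COC(=O)N[C@H](C(=O)NN(CCC[C@@](O)(Cc1ccccc1)C(=O)N[C@H]1c2ccccc2C[C@H]1O)Cc1ccc(-c2cncnc2)cc1)C(C)(C)C`) gives > 10000 nM as a limit too. Compound 3 (`COC(=O)N[C@H](C(=O)NN(CCC[C@@](O)(Cc1ccccc1)C(=O)N[C@H]1c2ccccc2C[C@H]1O)Cc1ccc(-c2csc(C)n2)cc1)C(C)(C)C`) gives > 10000 nM as a limit too. Together these make up the limit of > 10000 nM in this assay, at which 3 of the 3 values shown sit, and leave no exact number to work from. Compound 4 (`COC(=O)N[C@H](C(=O)NN(CCC[C@@](O)(Cc1ccccc1)C(=O)N[C@H]1c2ccccc2C[C@H]1O)Cc1ccc(OCc2cnc(Cl)s2)cc1)C(C)(C)C`) differs from compound 1 by one change ((2-chloro-1,3-thiazol-5-yl)methoxy in place of pyridin-2-yl on an aromatic carbon) with (2-chloro-1,3-thiazol-5-yl)methoxy in place of pyridin-2-yl. Two measured changes at the same place bear on it (a step that the two limits leave unreadable from compound 1 to compound 2 and a step that the two limits leave unreadable from compound 1 to compound 3) but neither has a size that can be carried over. No shift beyond the scatter is therefore expected in this assay and the expected step (a step that the limit leaves unreadable from compound 1 to compound 4) has no firm direction. For compound 4 the estimate is 15000 nM with an expected range from 6000 nM to 40000 nM in repeated measurements.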

Compound 4, half-maximal cytotoxic concentration: > 10000 nM
Compound 4 ended at the assay's limit; the forecaster's own chance of this, stated with the estimate: 85%; the middle value does not contradict the limit.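

Compound 1, compound 2, compound 3 and compound 4 all stop at the same limit, so no step between them can be read: the limit of > 10000 nM in this assay, at which 4 of the 4 values shown sit.

Still open is the exact concentration at which any of these compounds turns toxic in this assay, and whether the exchanged groups differ there.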